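Trimming the isobutyl chain of compound 3

This account rests on a few compounds, and the source may have more. Where it says the series, first, only, none or still open, it means among the compounds named here.

In a physicochemical assay for solubility, in phosphate buffer, measured as kinetic solubility, with a stated time of 24 h, at pH 7.4 (on this read-out lower numbers stand for lower solubility and higher numbers for higher solubility), compound 1 `COC1CCN(c2ccc(CN(CC(C)C)S(=O)(=O)Cc3ccccc3)cc2)CC1` gives <= 1000 nM which is a limit and not a number. Compound 2 `CC(C)CN(Cc1ccc(N2CCC(C(N)=O)CC2)cc1)S(=O)(=O)Cc1ccccc1` gives <= 1000 nM which is also a limit. Compound 3 `CC(=O)N1CCN(c2ccc(CN(CC(C)C)S(=O)(=O)Cc3ccccc3)cc2)CC1` gives <= 1000 nM which is likewise a limit. All three therefore share one position, the limit of <= 1000 nM in this assay, at which 3 of the 3 values shown sit, and so compound 3 cannot be ranked against the others.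

Compound 4 `CCCN(Cc1ccc(N2CCN(C(C)=O)CC2)cc1)S(=O)(=O)Cc1ccccc1` differs from compound 3 at one place hydrogen in place of methyl on a saturated chain carbon bound to two saturated chain carbons with hydrogen in place of methyl on a saturated chain carbon bound to two saturated chain carbons, so isobutyl becomes propyl.

The measured comparisons are a step that the two limits leave unreadable from compound 1 to compound 2 then a step that the two limits leave unreadable from compound 1 to compound 3 and finally a step that the two limits leave unreadable from compound 2 to compound 3 and none of them alters this chain. They offer no size or direction to carry over, so no step beyond the scatter is expected in this assay for this change. The expected step is a step that the limit leaves unreadable from compound 3 to compound 4 in this estimate. Compound 4 is estimated at 800 nM with an expected range from 200 nM to 2500 nM and another limit is the likeliest report.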

Compound 4, solubility: 40000 nM
For compound 4 the middle estimate is 50-fold (1.70 log units) below the measured one, outside the stated range (above it).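

The loss of a single methyl from the chain of compound 3 brings an at least 40-fold higher number from compound 3 to compound 4 (1.60 log units; beyond the scatter) in this assay. For the compounds shown here, this chain is therefore a place where a very small edit can move the read-out far, something the earlier steps could not show, since none of them can be read and none touches this chain. Compound 4 is also the only compound here with a value that can be read as a number, and the other compounds all remain at one shared position: the limit of <= 1000 nM in this assay, at which 3 of the 4 values shown sit.

From the compounds shown here alone, whether propyl would bring a step of similar size with the 4-methoxypiperidin-1-yl group of compound 1 or the 4-carbamoylpiperidin-1-yl group of compound 2 remains open. So does the outcome for an ethyl chain or for a propyl chain ending in an amine.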